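Swapping the Sulfur-Linked Ring for a Phenylpiperazine

The compounds below may be only part of what the source reports. "The series", "measured", "known", "first", "only" and "open" are said of these compounds alone.

Measured compounds:
compound 1 `Cn1c(-c2ccc(NC(=O)CSc3nc4ccccc4o3)cc2)nc(-c2ccccc2)c1-c1ccccc1`: 27.4%
compound 2 `Cn1c(-c2ccc(NC(=O)CSc3nc4ccccc4s3)cc2)nc(-c2ccccc2)c1-c1ccccc1`: 2.1%
compound 3 `Cn1c(-c2ccc(NC(=O)CSC3=NCCS3)cc2)nc(-c2ccccc2)c1-c1ccccc1`: 16.2%

In a functional assay on MCF7 cells (Homo sapiens) for cytotoxicity, read by MTT assay, with a stated time of 24 h, tested at 1.6 ug/mL (a higher number here means a stronger effect of the compound at the concentration tested, a lower number a weaker effect), compound 1 gives 27.4% and compound 2 gives 2.1%, while compound 3 gives 16.2%. Compound 3 therefore stands second highest of the three: it sits below compound 1 by the step of a number 11.2 percentage points lower from compound 1 to compound 3 (beyond the scatter) and above compound 2 by the step of a number 14.1 percentage points higher from compound 2 to compound 3 (beyond the scatter), both beyond the scatter. Among the measured compounds shown here, the only other measured step, a number 25.3 percentage points lower from compound 1 to compound 2 (beyond the scatter), is also modest in size.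

Compound 4 `Cn1c(-c2ccc(NC(=O)CN3CCN(c4ccccc4)CC3)cc2)nc(-c2ccccc2)c1-c1ccccc1` has not yet been measured. It differs from compound 3 as follows: a group of 12 heavy atoms (10 carbon, 2 nitrogen; one six-membered non-aromatic ring with 2 hetero atoms, one six-membered aromatic ring of carbon only) in place of a group of 6 heavy atoms (3 carbon, 1 nitrogen, 2 sulfur; one five-membered non-aromatic ring with 2 hetero atoms), on a saturated chain carbon bound to a carbonyl carbon. For the measured compounds named here, all three measured steps vary the ring attached to the sulfur, whereas here the sulfur and its ring leave altogether and a different kind of group enters, so none of the measured steps bears directly on this change. Since every measured step was modest, a modest step in either direction, or none beyond the scatter, is the reasonable expectation for this assay. Compound 4 is expected to give 15%, within a range of 3% to 35%. This estimate corresponds to an expected step of a number 1.2 percentage points lower from compound 3 to compound 4 (within the scatter).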

Compound 4, a percentage reported as activity, at one concentration (the size of the read-out at that concentration, not a potency): 21.3%
Estimate against measurement, compound 4: 6.3 percentage points below; the range from low to high includes it.
By their numbers in this assay, from the lowest: compound 2; then compounds 3, 4 and 1 (each within the scatter of the next, the first and the last beyond it).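

The sulfur and its ring are not required for this level of effect on the saturated chain carbon bound to a carbonyl carbon. In this assay, among the compounds shown here, 4-phenylpiperazin-1-yl, which contains no sulfur, stays within the scatter of two sulfur-linked compounds (a number 5.1 percentage points higher from compound 3 to compound 4 (within the scatter); a number 6.1 percentage points lower from compound 1 to compound 4 (within the scatter)), and only the step from the (1,3-benzothiazol-2-yl)sulfanyl compound is beyond it (a number 19.2 percentage points higher from compound 2 to compound 4 (beyond the scatter)). No measurement shown here accounts for these results.

The compounds shown cannot separate the contribution of the piperazine ring from that of its phenyl group, since no methyl group or hydrogen takes the phenyl's place on that ring. As far as these compounds go, how a morpholine or a simple dimethylamino group would compare on the same carbon also remains open.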